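A few compounds are considered here, and "the series" means these few. Any claim that something is new, unique, unknown or untested is made for them only; others in the source may bear on it.

Among the compounds with values here, the two compounds measured so far share one core and differ only in the group on an aromatic nitrogen. Compound 1 `CCOC(=O)c1c(-c2cc3ccccc3oc2=O)nn(-c2ccc(OC)cc2)c1C(=O)OCC` carries a 4-methoxyphenyl there and gives 39000 nM in a functional assay on DU-145 cells (Homo sapiens) for cytotoxicity, read by MTT assay, with a stated time of 48 h; a lower number here means a stronger inhibitor, a higher number a weaker inhibitor. Compound 2 `CCOC(=O)c1c(-c2cc3ccccc3oc2=O)nn(-c2cccc(F)c2)c1C(=O)OCC` carries a 3-fluorophenyl, and in this assay compound 2 gives 32000 nM. The step of a 1.2-fold lower number from compound 1 to compound 2 (0.09 log units; within the scatter) shows that the two numbers lie within the scatter of each other, so compound 2 stands at the lower of the two numbers without being set apart from compound 1.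

Compound 3 `CCOC(=O)c1c(-c2cc3ccccc3oc2=O)nn(-c2ccc(Br)cc2)c1C(=O)OCC` is not yet measured. It differs from compound 2 by 4-bromophenyl in place of 3-fluorophenyl on an aromatic nitrogen. Within the data shown here, the only measured step that bears on this change is the exchange of one aryl group for another at the same nitrogen, a 1.2-fold lower number from compound 1 to compound 2 (0.09 log units; within the scatter), which moved the number by no more than the scatter. On that basis a step of no size beyond the scatter is expected for a 1.0-fold higher number from compound 2 to compound 3 (0.01 log units; within the scatter). The estimate for compound 3 in this assay is therefore 33000 nM, with a range from 12000 nM to 90000 nM.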

Compound 3, half-maximal inhibitory concentration: 61000 nM
Compound 3: middle estimate off by 1.8-fold (0.27 log units), on the low side, within the range that was stated.
By their numbers in this assay, from the lowest: compounds 2, 1 and 3 (each within the scatter of the next).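

In this assay, a third aryl group on the aromatic nitrogen again fails to set any compound apart, with a 1.9-fold higher number from compound 2 to compound 3 (0.28 log units; within the scatter), so 4-bromophenyl, 3-fluorophenyl and 4-methoxyphenyl cannot be told apart at this position. Within the data shown here, the pair of compound 1 and compound 3 adds a cleaner comparison than the earlier compounds offered, since only one substituent on the aryl ring changes, bromo in place of methoxy on an aromatic carbon, and that exchange gives a 1.6-fold higher number from compound 1 to compound 3 (0.19 log units; within the scatter). Nothing available on these compounds offers an explanation for the numbers.

All three compounds carry a substituted phenyl on this nitrogen, so the compounds shown leave open whether a group of another kind there, such as an unsubstituted alkyl chain, a benzyl group or a phenyl bearing an amine or a carboxylic acid, would move the number beyond the scatter. They also leave open whether any change elsewhere on the shared core, for instance a carboxylic acid or an amide in place of an ethoxycarbonyl group, would matter more than the aryl group does.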